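The source may report more compounds than this note shows. Statements on the series, on what has been measured and on what is new or still open speak of the compounds shown alone.

Compound 1 `COc1cc(OC)c2c(=O)cc(C(=O)Nc3ccc(C4CCCCC4)cc3)[nH]c2c1` — a limit only in a functional assay on SUP-B15 cells (Homo sapiens) for antiproliferative activity, with a stated time of 72 h; on this read-out higher numbers stand for an effect only at larger amounts of compound and lower numbers for an effect already at smaller amounts: > 43100 nM
Compound 2 `COc1cc(OC)c2c(=O)cc(C(=O)Nc3ccc(N4CCN(C)CC4)cc3)[nH]c2c1` — a limit only in this assay : > 19800 nM

Compound 2 therefore stands at the limit of this assay, not at a number. For the measured compounds named here, the single measured step, a step that the two limits leave unreadable from compound 1 to compound 2, is unreadable because both ends sit at limits, the limit of > 19800 nM in this assay, at which 1 of the 2 values shown sits, and (the limit of > 43100 nM in this assay, at which 1 of the 2 values shown sits). Compound 3 `COc1cc(OC)c2c(=O)cc(C(=O)Nc3ccc(Oc4ccc([N+](=O)[O-])cc4)cc3)[nH]c2c1` differs from compound 2 by 4-nitrophenoxy in place of 4-methylpiperazin-1-yl on an aromatic carbon. No readable step bears on this change, so neither direction nor size can be drawn from the measurements. Compound 3 is expected at 20000 nM, within 4000 nM to 60000 nM. The estimated step is a step that the limit leaves unreadable from compound 2 to compound 3.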

Compound 3, half-maximal effective concentration: 4300 nM
Beside the measured number, compound 3's estimate is 4.7-fold (0.67 log units) above it; low and high end bracket the measured number.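

In this assay this place, para to a large group, proves able to move the read-out from a limit to a number: 4-nitrophenoxy brings an at least 4.6-fold lower number from compound 2 to compound 3 (0.66 log units; beyond the scatter) and an at least 10-fold lower number from compound 1 to compound 3 (1.00 log units; beyond the scatter). The first size is only a minimum because compound 2 stands at a limit: the limit of > 19800 nM in this assay, at which 1 of the 3 values shown sits. The second is a minimum for the same reason, as compound 1 also stands at a limit: the limit of > 43100 nM in this assay, at which 1 of the 3 values shown sits.

Going by these compounds, whether the change rests on the nitro group, the aromatic ring or the linking oxygen stays open. A plain phenoxy or a 4-aminophenoxy group in this place would help to tell.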